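The compounds below may be only part of what the source reports. "The series", "measured", "known", "first", "only" and "open" are said of these compounds alone.

Compound 1 `Cn1nccc1-c1ccccc1NCC1=NCCN1` and compound 2 `Cc1n[nH]c(-c2ccccc2NCC2=NCCN2)n1` share a core bearing a five-membered heteroaromatic ring. In a functional assay with Alpha-1B adrenergic receptor (Homo sapiens) as the target, read by calcium flux (on this read-out higher numbers stand for larger maximal responses and lower numbers for smaller maximal responses), compound 1 gives 0%. In this assay compound 2 gives 0%, so compound 2 stands level with compound 1 at the digits shown, and the step of no change at the digits printed from compound 1 to compound 2 (within the scatter) lay within the scatter although 3-methyl-1H-1,2,4-triazol-5-yl had replaced 1-methyl-1H-pyrazol-5-yl on an aromatic carbon. Compound 3 `Cn1ccc(-c2ccccc2NCC2=NCCN2)n1` has not yet been measured; it differs from compound 2 in one place: 1-methyl-1H-pyrazol-3-yl in place of 3-methyl-1H-1,2,4-triazol-5-yl on an aromatic carbon. Among the compounds with values here, the only measured step that bears on this change is the one from compound 1 to compound 2, which also swapped one five-membered ring for another on an aromatic carbon of the core and produced no shift. On that basis no step beyond the scatter is expected in this assay, and the estimated step for compound 3 is no change at the digits printed from compound 2 to compound 3 (within the scatter). Compound 3 is therefore expected to give 0%, within a range from 0% to 10%.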

Compound 3, largest response reached (reported as maximal response), in percent of the reference or control that the assay uses: 33%
Beside the measured number, compound 3's estimate is 33 percentage points below it; the measured number lies above the stated range.
By their numbers in this assay, from the lowest: compounds 1 and 2 (each within the scatter of the next); then compound 3.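

In this assay the choice of five-membered ring at this aromatic carbon does matter, which the step between the two earlier compounds had not shown: 1-methyl-1H-pyrazol-3-yl in place of 3-methyl-1H-1,2,4-triazol-5-yl gives a number 33 percentage points higher from compound 2 to compound 3 (beyond the scatter) on this read-out. The comparison of the two pyrazoles is the narrower one, as 1-methyl-1H-pyrazol-3-yl in place of 1-methyl-1H-pyrazol-5-yl keeps the same ring and methyl group and alters only how the ring is joined to the core, yet it gives a number 33 percentage points higher from compound 1 to compound 3 (beyond the scatter) as well. Nothing given here accounts for either step.

Going by these compounds, it remains open whether the response at this carbon depends on the methyl group of the pyrazole, as a pyrazole without it would show. On these data alone, it is equally open how a six-membered ring such as pyridine, or an open-chain group such as a primary amide, would fare in its place.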